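The source may hold more compounds than are shown below. What is called first, only, known or untested is meant among the compounds shown, and "the series" means these compounds.

Measured compounds in a functional assay on G-361 cells (Homo sapiens) for cytotoxicity, read by sulforhodamine B assay; on this read-out higher numbers stand for weaker inhibition of growth and lower numbers for stronger inhibition of growth:
- compound 1 `CCCNc1nc(C)nc2c1cnn2-c1ccccc1`: > 100000 nM
- compound 2 `CCCCNc1nc(C)nc2c1cnn2-c1ccccc1`: > 100000 nM

Both values are limits of this assay, not numbers. For compound 1 this assay gives only a limit, > 100000 nM. For compound 2 this assay likewise gives only a limit, > 100000 nM. Going by the values given here, the single measured step, a step that the two limits leave unreadable from compound 1 to compound 2, is therefore unreadable, and both values sit at the limit of > 100000 nM in this assay, at which 2 of the 2 values shown sit. On the numbers shown compound 2 stands at the limit and nowhere more precise.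

Compound 3 `Cc1nc(NCc2ccco2)c2cnn(-c3ccccc3)c2n1` differs from compound 2 by furan-2-yl in place of propyl on a saturated chain carbon bound to a nitrogen on an aromatic ring; cut one bond further out, the change reads butyl to (furan-2-yl)methyl, or butylamino to ((furan-2-yl)methyl)amino. Among the compounds with values here, no measured step bears on this change, since the only step cannot be sized. Compound 3 is expected near 100000 nM, with a range from 30000 nM to 300000 nM. The expected step of a number no higher from compound 2 to compound 3 (the limit leaves the size open) is thus none beyond the scatter, with the limit the most likely outcome.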

Compound 3, concentration for total growth inhibition: > 100000 nM
Compound 3 gave a limit, no number; the forecaster's own chance of this, stated with the estimate: 75%; the middle value lies on the limit itself.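

No new step can be read: compound 3, like compound 1 and compound 2, gives a limit and not a number in this assay, so the steps among them cannot be read: the limit of > 100000 nM in this assay, at which 3 of the 3 values shown sit.

The compounds shown leave open whether any of these chains on the shared core gives a measurable growth inhibition.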